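Dropping a trifluoromethyl from a dopamine receptor ligand

This account rests on a few compounds, and the source may have more. Where it says the series, first, only, none or still open, it means among the compounds named here.

Compound 1 `FC(F)(F)c1nc2c(-[n+]3cc[n+](Cc4ccccc4)cc3)cccc2[nH]1` was tested in an assay on isolated protein for binding affinity to D(4) dopamine receptor (Homo sapiens) (a lower number here means a stronger inhibitor, a higher number a weaker inhibitor), where compound 1 gives 2.9 nM. Its closest companion is compound 2 `Clc1ccc2[nH]ccc2c1-[n+]1cc[n+](Cc2ccccc2)cc1`, which in this assay gives 1.7 nM; the two numbers lie within the usual scatter of each other, so the data do not separate them. Compound 3 `c1ccc(C[n+]2cc[n+](-c3cccc4[nH]cnc34)cc2)cc1` has not been measured. It differs from compound 1 in one place: hydrogen in place of trifluoromethyl on an aromatic carbon. Within the data shown here, no measured pair shows this change, so only a modest step is expected, if any, toward a weaker inhibitor. Compound 3 is expected to give 6 nM, within 1.5 nM to 25 nM, a step estimated as a 2.1-fold higher number from compound 1 to compound 3 (0.32 log units; beyond the scatter).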

Compound 3, inhibition constant: 47 nM
For compound 3 the middle estimate is 7.8-fold (0.89 log units) below the measured one; the measured number lies above the stated range.
By their numbers in this assay, from the lowest: compounds 2 and 1 (each within the scatter of the next); then compound 3.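

Replacing trifluoromethyl with hydrogen on this carbon, between two ring nitrogen atoms, is a large loss in this assay (a 16-fold higher number from compound 1 to compound 3 (1.21 log units; beyond the scatter)). The group at this position therefore matters greatly for the number in this assay, and the core of compound 3 alone does not keep the strength of compound 1. Nothing available here explains why this change has so large an effect.

Going by these compounds, whether a methyl or an amine on this carbon would bring a number closer to compound 1 or to compound 3 stays open. This single pair also cannot tell whether the same change would cost as much on a different core.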